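The compounds below may be only part of what the source reports. "The series", "measured", "known", "first", "only" and "open" are said of these compounds alone.

Compound 1 `COc1cc(N2C(=O)[C@@H](Oc3ccccc3)[C@H]2c2ccc3ccccc3c2)cc(OC)c1OC` and compound 2 `COc1cc(N2C(=O)[C@@H](Oc3ccccc3)[C@H]2c2ccc(N=[N+]=[N-])cc2)cc(OC)c1OC` were both tested in a functional assay on MCF7 cells (Homo sapiens) for antiproliferative activity, read by MTT assay, with stated times of 24 h and 72 h; a lower number here means a stronger inhibitor, a higher number a weaker inhibitor. Compound 1 gives 282000 nM, while compound 2 gives 23000 nM, the lowest of the two numbers, and the step of a 12-fold lower number from compound 1 to compound 2 (1.09 log units; beyond the scatter) is large. Compound 3 `COc1cc(N2C(=O)[C@@H](Oc3ccccc3)[C@H]2c2cc(N)c(OC)c(O)c2)cc(OC)c1OC` has not been measured. It differs from compound 2 in one place: a group of 10 heavy atoms (7 carbon, 1 nitrogen, 2 oxygen; one six-membered aromatic ring of carbon only) in place of a group of 9 heavy atoms (6 carbon, 3 nitrogen; one six-membered aromatic ring of carbon only), on a saturated ring carbon. Within the data shown here, the only measured step at this position is the one from compound 1 to compound 2, which did not involve the entering group, so the direction of the new step is open. Compound 3 is expected to give 20000 nM, with a range from 5000 nM to 80000 nM. The expected step is a 1.2-fold lower number from compound 2 to compound 3 (0.06 log units; within the scatter), within the scatter.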

Compound 3, half-maximal inhibitory concentration: 8800 nM
Beside the measured number, compound 3's estimate is 2.3-fold (0.36 log units) above it; measured number inside the range.
By their numbers in this assay, from the lowest: compound 3; then compound 2; then compound 1.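

Moving from 4-azidophenyl to the entering group, which carries hydrogen-bond donors where 4-azidophenyl has none, gives a 2.6-fold lower number from compound 2 to compound 3 (0.42 log units; beyond the scatter) in this assay, so this position tolerates such a group on the aromatic ring. Against naphthalen-2-yl, with the same count of heavy atoms, the change is a 32-fold lower number from compound 1 to compound 3 (1.51 log units; beyond the scatter), so that count alone does not set the number. Nothing available accounts for either step. The compounds shown do not separate the contributions of the amine, methoxy and hydroxyl groups on the entering ring. From the compounds shown here alone, how a plain 4-aminophenyl or 4-hydroxyphenyl group would compare remains open.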